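The source may report more compounds than this note shows. Statements on the series, on what has been measured and on what is new or still open speak of the compounds shown alone.

In a functional assay on DU-145 cells (Homo sapiens) for antiproliferative activity, read by WST assay, with a stated time of 72 h (on this read-out higher numbers stand for an effect only at larger amounts of compound and lower numbers for an effect already at smaller amounts), compound 1 `CCCCCCCCCCc1c(C)c(CCCCCCCCCC)c2[n+](c1C)CCC2` gives 1.31 uM and compound 2 `CCCCCCCC/C=C\c1c(C)c(/C=C\CCCCCCCC)c2[n+](c1C)CCC2` gives 1.02 uM, so the two values lie within the usual scatter of each other. Compound 3 `CCCCCCCC/C=C/c1c(C)c(/C=C/CCCCCCCC)c2[n+](c1C)CCC2` departs from compound 2 in configuration alone (the two compounds have the same atoms and bonds and differ only in configuration as drawn: 2 of 2 stereo elements differ; a double bond is drawn Z in compound 2 and E in compound 3; a double bond is drawn Z in compound 2 and E in compound 3), with both double bonds drawn Z in compound 2 and E in compound 3. Among the measured compounds shown here, no measured pair isolates this change. In this assay no shift beyond the scatter is expected, in either direction. The expected step of a 1.1-fold higher number from compound 2 to compound 3 (0.03 log units; within the scatter) is estimated to stay within that scatter. Compound 3 is estimated at 1.1 uM, with an expected range from 0.45 uM to 2.8 uM for the measurement.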

Compound 3, concentration for half-maximal effect: 0.84 uM
For compound 3 the middle estimate is 1.3-fold (0.12 log units) above the measured one; measured number inside the range.
By their numbers in this assay, from the lowest: compounds 3, 2 and 1 (each within the scatter of the next).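

In this assay, among the compounds shown here, the first pair to isolate double-bond configuration gives a 1.2-fold lower number from compound 2 to compound 3 (0.08 log units; within the scatter) and so shows no shift beyond the scatter when both double bonds change from Z to E. With these two chains on the shared core, the geometry of the double bonds has no measurable bearing on the read-out. The comparison reads on configuration alone: the fact that compounds 2 and 3 differ only in the configuration as drawn.

Still open, on these data alone, is how a compound with one Z and one E double bond would behave. Also open, as far as these compounds go, is whether a shorter chain, or a chain ending in an amine or a carboxylic acid, would stay in the same range.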